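Aryl-substituent step from compound 3 to compound 4

The source may hold more compounds than are shown below. What is called first, only, known or untested is meant among the compounds shown, and "the series" means these compounds.

The series shares the core seen in compound 1 `CN(Cc1cccc(F)c1)C(=O)CCCNC(=O)c1ccc(S(C)(=O)=O)c([N+](=O)[O-])c1`. In an ADME assay on HepG2 cells (Homo sapiens) for cytotoxicity, read by CellTiter-Glo and ATP content, with a stated time of 72 h (a lower number here means that less compound is needed, a higher number that more compound is needed for the effect), compound 1 gives only a limit, > 27000 nM. Compound 2 `CN(CC(=O)N1CCN(c2ccc(F)cc2)CC1)C(=O)c1ccc(S(C)(=O)=O)c([N+](=O)[O-])c1` carries a fluoro group on an aromatic carbon, and in this assay compound 2 gives 17200 nM. Compound 3 `CN(CC(=O)N1CCN(c2ccccc2)CC1)C(=O)c1ccc(S(C)(=O)=O)c([N+](=O)[O-])c1` carries hydrogen in that place. In this assay compound 3 gives only a limit, > 27000 nM. Among the compounds with values here, the single one-point step measured so far, an at least 1.5-fold higher number from compound 2 to compound 3 (0.19 log units; that floor lies within the scatter), sits within the scatter, and its size is bounded because of the limit of > 27000 nM in this assay, at which 2 of the 3 values shown sit.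

Compound 4 `CN(CC(=O)N1CCN(c2ccc(C(F)(F)F)cc2)CC1)C(=O)c1ccc(S(C)(=O)=O)c([N+](=O)[O-])c1` differs from compound 3 by trifluoromethyl in place of hydrogen on an aromatic carbon. Within the data shown here, no measured step covers this group. Among the measured compounds shown here, the one step available, an at least 1.5-fold higher number from compound 2 to compound 3 (0.19 log units; that floor lies within the scatter), together with the limit of > 27000 nM in this assay, at which 2 of the 3 values shown sit, shows only that changing the group on this aromatic carbon has so far moved nothing beyond the scatter in this assay. For compound 4 a step of a number no higher from compound 3 to compound 4 (the limit leaves the size open) in this assay is therefore expected, that is none beyond the scatter, and the result may again come back as a limit. Compound 4 is estimated at 27000 nM in this assay, with a range from 12000 nM to 60000 nM.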

Compound 4, half-maximal effective concentration: 11900 nM
The estimate for compound 4 lay 2.3-fold (0.36 log units) above the measured number; measured number outside the range, below it.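

Trifluoromethyl in place of hydrogen on this aromatic carbon, para to a large group, gives an at least 2.2-fold lower number from compound 3 to compound 4 (0.35 log units; beyond the scatter) in this assay, the first step at this position to lie beyond the scatter. Trifluoromethyl in place of fluoro gives a 1.4-fold lower number from compound 2 to compound 4 (0.16 log units; within the scatter), so the two compounds with a group other than hydrogen here cannot be told apart, and the data show a shift that separates hydrogen from both groups rather than an order between fluoro and trifluoromethyl. The full size of the step from hydrogen to trifluoromethyl stays open because compound 3 stands at a limit of the assay: the limit of > 27000 nM in this assay, at which 2 of the 4 values shown sit.

With only fluoro and trifluoromethyl shown as replacements for hydrogen at this position, it remains open whether an amine, a carboxylic acid or a methoxy group would also give a lower number than hydrogen in this assay. From the compounds shown here alone, it also remains open whether trifluoromethyl on another carbon of the same ring would give a step of similar size, or whether the step is tied to this one position.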